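The source may hold more compounds than are shown below. What is called first, only, known or untested is meant among the compounds shown, and "the series" means these compounds.

Of the compounds shown here, two sharing one core have so far been measured in an ADME assay on A549 cells (Homo sapiens) for cytotoxicity, read by MTT assay; a higher number here means that more compound is tolerated, a lower number that less compound is tolerated. Compound 1 `O=c1[nH]c(=O)n([C@@H]2O[C@H](CO)[C@@H](O)[C@H]2O)cc1C#CC1CCCCC1` gives 127000 nM in this assay, and compound 2 `CCCCC#Cc1cn([C@@H]2O[C@H](CO)[C@@H](O)[C@H]2O)c(=O)[nH]c1=O` gives 83200 nM. For the measured compounds named here, the one step between them is a 1.5-fold lower number from compound 1 to compound 2 (0.18 log units; within the scatter), so compound 2 stands nearest compound 1 and the two cannot be told apart on these numbers.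

Compound 3 `O=c1[nH]c(=O)n([C@@H]2O[C@H](CO)[C@@H](O)[C@H]2O)cc1C#CC(O)c1ccccc1` has not yet been measured. It differs from compound 2 in one place: hydroxy(phenyl)methyl in place of butyl on a triple-bonded carbon. Going by the values given here, the only measured step that bears on this change is the one from compound 1 to compound 2, which also exchanged the group on the triple-bonded carbon and stayed within the scatter. Nothing in the data shows that a change on the triple-bonded carbon moves the number in this assay beyond the scatter, so the step of a 1.1-fold higher number from compound 2 to compound 3 (0.03 log units; within the scatter) is expected to stay within it. Compound 3 is therefore estimated to give 90000 nM in this assay, with a range from 40000 nM to 200000 nM.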

Compound 3, half-maximal cytotoxic concentration: 34200 nM
Beside the measured number, compound 3's estimate is 2.6-fold (0.42 log units) above it; measured number below the stated range.
By their numbers in this assay, from the lowest: compound 3; then compounds 2 and 1 (each within the scatter of the next).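

The group on the triple-bonded carbon can move the number in this assay beyond the scatter: hydroxy(phenyl)methyl in place of butyl gives a 2.4-fold lower number from compound 2 to compound 3 (0.39 log units; beyond the scatter), and hydroxy(phenyl)methyl in place of cyclohexyl gives a 3.7-fold lower number from compound 1 to compound 3 (0.57 log units; beyond the scatter), both modest steps towards less compound tolerated. A ring alone does not separate these compounds, as compound 1 carries cyclohexyl and stays within the scatter of compound 2, so what sets compound 3 apart is among the things that enter together: the aromatic ring, the oxygen and the hydrogen-bond donor. No supporting evidence is available to explain the lower number in compound 3.

The compounds shown do not separate the hydroxy group from the phenyl ring: a plain benzyl group or a hydroxymethyl group on the triple-bonded carbon would each carry only one of the two. Also open, on these data alone, is whether an amine in place of the hydroxy group, or a chain longer than butyl, would lower the number further or leave it within the scatter of compound 2.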